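The source may report more compounds than this note shows. Statements on the series, on what has been measured and on what is new or still open speak of the compounds shown alone.

Compound 1 `Clc1ccc(C2CC(c3ccccc3)=NN2c2ccc(-c3ccccc3)nn2)cc1` gives 100000 nM in a functional assay on Caco-2 cells (Homo sapiens) for antiproliferative activity, read by MTT assay, with a stated time of 24 h; a higher number here means a weaker inhibitor, a lower number a stronger inhibitor.
Compound 2 `COc1ccc(C2=NN(c3ccc(-c4ccccc4)nn3)C(c3ccc(Cl)cc3)C2)cc1` reaches only a limit of this assay in compound 2, > 100000 nM.
Compound 3 `COc1ccc(C2=NN(c3ccc(-c4ccccc4)nn3)C(c3ccc(OC)cc3)C2)cc1` likewise reaches only a limit in compound 3, > 100000 nM.

All three values sit at or at the edge of the assay range, as the limit of > 100000 nM in this assay, at which 2 of the 3 values shown sit, shows. The change methoxy in place of hydrogen on an aromatic carbon made the step of a number no lower from compound 1 to compound 2 (the limit leaves the size open), and the change from compound 2 to compound 3 made a step that the two limits leave unreadable from compound 2 to compound 3. How the core of compound 1 differs from that of compound 3 is not broken down here. Compound 4 `COc1ccc(C2=NN(c3ccc(-c4ccccc4)nn3)C(c3ccc(OC)cc3OC)C2)cc1` carries the same kind of change, (methoxy in place of hydrogen on an aromatic carbon), though ortho to a large group and meta to a methoxy group rather than para to a large group. Since compound 3 stands at the limit > 100000 nM, compound 4 is expected to stay there too, a step of a number no higher from compound 3 to compound 4 (the limit leaves the size open). Compound 4 is estimated at 100000 nM.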

Compound 4, half-maximal inhibitory concentration: > 100000 nM
Compound 4: a limit, no number; the forecaster's own chance of this, stated with the estimate: 85%; the middle value lies on the limit itself.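

Compound 4 also stands only at a limit, so no step to it from compound 2 or compound 3 can be read: the limit of > 100000 nM in this assay, at which 3 of the 4 values shown sit.

The compounds shown leave open how far compound 2, compound 3 and compound 4 lie beyond that limit in this assay.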